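This account rests on a few compounds, and the source may have more. Where it says the series, first, only, none or still open, it means among the compounds named here.

Among the measured compounds shown here, compound 1 `COc1cc(-c2cc(/C=C/C(=O)c3ccc(N)cc3)[nH]n2)cc(OC)c1OC` gives 6200 nM in a functional assay on MDA-MB-435 cells (Homo sapiens) for inhibition, read by sulforhodamine B assay, with a stated time of 48 h (a higher number here means that more compound is tolerated, a lower number that less compound is tolerated), which stands as the higher of the two numbers so far, though only by a margin within the scatter. Compound 2 `COc1ccc(C(=O)/C=C/c2cc(-c3cc(OC)c(OC)c(OC)c3)n[nH]2)cc1OC` gives 5520 nM in this assay, and the step of a 1.1-fold lower number from compound 1 to compound 2 (0.05 log units; within the scatter) lies within the scatter. Compound 3 `COc1ccc(C(=O)/C=C/c2cc(-c3cc(OC)c(OC)c(OC)c3)n[nH]2)cc1` carries methoxy in place of amino on an aromatic carbon. For the measured compounds named here, the only measured step also exchanges the aryl group on the carbonyl carbon and changes little, so a step within the scatter is expected for a 1.1-fold lower number from compound 1 to compound 3 (0.05 log units; within the scatter). Compound 3 is therefore expected to give 5500 nM, between 2700 nM and 11000 nM.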

Compound 3, concentration lethal to 50% of the cells: > 100000 nM
Compound 3: only a limit was reported (the forecaster's own chance of this, stated with the estimate: 3%); at least 18-fold (1.25 log units) between middle value and limit.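

The aryl group on the carbonyl carbon proves far less indifferent than the earlier step suggested. Methoxy in place of amino gives an at least 16-fold higher number from compound 1 to compound 3 (1.20 log units; beyond the scatter), and hydrogen in place of methoxy gives an at least 18-fold higher number from compound 2 to compound 3 (1.25 log units; beyond the scatter), so the 4-methoxyphenyl of compound 3 departs from both the 4-aminophenyl and the 3,4-dimethoxyphenyl group. The value of compound 3 is a limit: the limit of > 100000 nM in this assay, at which 1 of the 3 values shown sits.

As far as these compounds go, how far compound 3 lies past that limit stays open. So does whether a hydroxyl or a dimethylamino group on the same aromatic carbon would behave like amino or like methoxy.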